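Ethylamino Replaces Pyridin-3-yl on the Acyl Carbonyl

The source may report more compounds than this note shows. Statements on the series, on what has been measured and on what is new or still open speak of the compounds shown alone.

Compound 3 `Cc1nn(C(=O)c2cccnc2)c(N)c1-c1ccc(Cl)c(Cl)c1` carries a pyridin-3-yl on its carbonyl carbon. In an assay on Sf9 cells for inhibition of mitogen-activated protein kinase kinase kinase 14 (Homo sapiens), read by ADP-Glo, with a stated time of 60 min (on this read-out higher numbers stand for weaker inhibition and lower numbers for stronger inhibition), compound 3 gives only a limit, > 100000 nM. Its two closest measured relatives are compound 1 `CCC(=O)n1nc(C)c(-c2ccc(Cl)c(Cl)c2)c1N`, which in this assay gives 27400 nM, and compound 2 `Cc1nn(C(=O)c2ccccc2)c(N)c1-c1ccc(Cl)c(Cl)c1`, which in this assay gives 23000 nM. The steps of an at least 3.6-fold higher number from compound 1 to compound 3 (0.56 log units; beyond the scatter) and an at least 4.3-fold higher number from compound 2 to compound 3 (0.63 log units; beyond the scatter) place compound 3 at the weak end of the three, while a 1.2-fold lower number from compound 1 to compound 2 (0.08 log units; within the scatter) shows that ethyl and phenyl on the carbonyl carbon give much the same result. Compound 4 `CCNC(=O)n1nc(C)c(-c2ccc(Cl)c(Cl)c2)c1N` differs from compound 3 by ethylamino in place of pyridin-3-yl on a carbonyl carbon. Of the measured steps, the two that reach compound 3 from compound 1 and from compound 2 bear on this change, both of them exchanging the pyridin-3-yl for another group; a step back toward the numbers of compound 1 and compound 2 is therefore expected, with stronger inhibition. Ethylamino itself is untested here, so the estimate carries wide bounds. For compound 4 in this assay a value of 40000 nM is expected, between 15000 nM and 150000 nM. That estimate means an expected step of an at least 2.5-fold lower number from compound 3 to compound 4 (0.39 log units; beyond the scatter), and a result reported only as a limit is expected to remain possible.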

Compound 4, half-maximal inhibitory concentration: > 100000 nM
Compound 4 gave a limit, no number (the forecaster's own chance of this, stated with the estimate: 35%); middle value at least 2.5-fold (0.39 log units) from the limit.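

Ethylamino on this carbonyl carbon gives a clearly higher number than ethyl (an at least 3.6-fold higher number from compound 1 to compound 4 (0.56 log units; beyond the scatter)) and than phenyl (an at least 4.3-fold higher number from compound 2 to compound 4 (0.63 log units; beyond the scatter)). Compound 3 is no longer alone at the limit, since compound 4, which carries a small group with no ring, also gives a limit rather than a number, so reaching that limit is not peculiar to pyridin-3-yl, although compound 1 and compound 2 stay readable: the limit of > 100000 nM in this assay, at which 2 of the 4 values shown sit. With both compounds reported only as limits, the step between compound 3 and compound 4 cannot be read.

As far as these compounds go, how pyridin-3-yl and ethylamino rank against each other therefore stays open. Also open, from the compounds shown here alone, is whether a methoxy, a dimethylamino or a longer carbon chain on this carbonyl carbon would stay readable like ethyl and phenyl or reach the limit.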